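The compounds below may be only part of what the source reports. "The series", "measured", "known", "first", "only" and "open" are said of these compounds alone.

Working notes on the series. The shared core is that of compound 1, `CCOC(=O)C1=C(Nc2ccccc2)S/C(=C\c2ccc(O)c(O)c2)C1=O`, and in a functional assay on MCF7 cells (Homo sapiens) for inhibition, read by MTT assay, with a stated time of 72 h, tested at 10 uM (a higher number here means more inhibition at the concentration tested (going by the name of the read-out), a lower number less inhibition), compound 1 gives 38.1%. Of the two numbers shown compound 1 stands lowest, nearest to compound 2, `CCOC(=O)C1=C(Nc2ccccc2)S/C(=C\c2ccc([N+](=O)[O-])c(O)c2)C1=O`, which in this assay gives 41.5%; the step is a number 3.4 percentage points higher from compound 1 to compound 2 (within the scatter). Compound 3, `CCOC(=O)C1=C(Nc2ccccc2)S/C(=C\c2ccc(C(=O)O)cc2)C1=O`, gives in this assay < 10%, which is a limit of the assay and not a number (the limit of < 10% in this assay, at which 1 of the 3 values shown sits). From there the step is a number at least 28.1 percentage points lower from compound 1 to compound 3 (beyond the scatter).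

Compound 4, `CCOC(=O)C1=C(Nc2ccccc2)S/C(=C\c2cccc(C(=O)O)c2)C1=O`, is not yet measured in this assay. The change from compound 1 is 3-carboxyphenyl in place of 3,4-dihydroxyphenyl on a double-bonded chain carbon bound to a double-bonded ring carbon. Of the measured steps only a number at least 28.1 percentage points lower from compound 1 to compound 3 (beyond the scatter) bears on this: the same 3,4-dihydroxyphenyl leaves, and a carboxyphenyl group, there the 4-carboxyphenyl, here the 3-carboxyphenyl, enters at the same place. A downward step of comparable size, beyond the scatter, is therefore expected, with a fair chance that only a limit is reported.

In this assay compound 4 is expected to give about 10%. The expected range for compound 4 runs from 0% to 25%. This estimate means a step of a number 28.1 percentage points lower from compound 1 to compound 4 (beyond the scatter).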

Compound 4, a percentage reported as inhibition, at one concentration (the size of the read-out at that concentration, not a potency): < 10%
Compound 4: no number, only a limit; the forecaster's own chance of this, stated with the estimate: 60%; the middle value lies on the limit itself.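

In this assay, replacing the 3,4-dihydroxyphenyl group with 3-carboxyphenyl at this double-bonded chain carbon gives a number at least 28.1 percentage points lower from compound 1 to compound 4 (beyond the scatter), so the fall seen with the 4-carboxyphenyl group of compound 3 is not confined to that one carboxyphenyl isomer. Compound 4 gives < 10%, which is a limit of the assay and not a number. The step between compound 3 and compound 4 cannot be read, so the two carboxyphenyl groups cannot be ranked against each other, and both compounds rest on the same limit: the limit of < 10% in this assay, at which 2 of the 4 values shown sit.

As far as these compounds go, whether the fall follows the entering carboxylic acid or the leaving hydroxy groups stays open, as the two changes go together in both steps down, and an unsubstituted phenyl or the methyl ester of the acid at the same place would separate them. The ethyl ester and the phenylamino group of the shared core are constant across all the compounds shown, so what an amide in place of that ester would do also remains open.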